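Thiazolylamide series, HepG2 growth inhibition, outlook for compound 3

This account rests on a few compounds, and the source may have more. Where it says the series, first, only, none or still open, it means among the compounds named here.

Measured so far:
compound 1 `Cc1cnc(NC(=O)COc2ccc(/C=C3\SC(=O)NC3=O)cc2)s1`: < 100000 nM
compound 2 `O=C(COc1ccc(/C=C2\SC(=O)NC2=O)cc1)Nc1nc2ccccc2s1`: < 100000 nM

In a functional assay on HepG2 cells (Homo sapiens) for cytotoxicity, read by sulforhodamine B assay, with a stated time of 48 h (a higher number here means a weaker inhibitor of growth, a lower number a stronger inhibitor of growth), compound 1 gives < 100000 nM, which is a limit of the assay and not a number. In this assay compound 2 gives < 100000 nM, again a limit rather than a number. Both shown values sit at the limit of < 100000 nM in this assay, at which 2 of the 2 values shown sit, so the single measured step, a step that the two limits leave unreadable from compound 1 to compound 2, cannot be read in either direction or size. Compound 2 therefore stands only at a limit, with no numbered value among the shown compounds to place it against.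

Compound 3 `O=C(COc1ccc(/C=C2\SC(=O)NC2=O)cc1)Nc1ncc([N+](=O)[O-])s1` follows from compound 2 by 5-nitro-1,3-thiazol-2-yl in place of 1,3-benzothiazol-2-yl on an amide-type nitrogen; the entering group carries one double bond outside aromatic rings. For the measured compounds named here, no measured step bears readably on this change, since the only one available is unreadable between two limits. With nothing in the shown numbers pulling either way, compound 3 is expected to remain at or beneath the same limit, and the estimate for compound 3 in this assay is 30000 nM, with a range from 5000 nM to 100000 nM. The step that the limit leaves unreadable from compound 2 to compound 3 that this estimate implies is expected to lie within the scatter.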

Compound 3, concentration for total growth inhibition: < 100000 nM
Compound 3 ended at the assay's limit; the forecaster's own chance of this, stated with the estimate: 70%; the middle value lies beyond the limit too.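

No step can be read among compound 1, compound 2 and compound 3, since all three values are limits of the assay and not numbers: the limit of < 100000 nM in this assay, at which 3 of the 3 values shown sit.

The compounds shown leave open whether, and how far, the 5-methyl-1,3-thiazol-2-yl, 1,3-benzothiazol-2-yl and 5-nitro-1,3-thiazol-2-yl groups on the amide-type nitrogen differ in growth inhibition.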